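Chloro Exchanged for a Hydroxypentyl Chain on a Shared Core

A few compounds are considered here, and "the series" means these few. Any claim that something is new, unique, unknown or untested is made for them only; others in the source may bear on it.

Measured compounds and their values:
compound 1 `FC(F)(F)c1ccccc1-c1nc(-c2ccc3nc[nH]c3c2)no1`: 4.78 10^-6 cm/s
compound 2 `Brc1ccc(-c2nc(-c3ccc4nc[nH]c4c3)no2)cc1`: 11.2 10^-6 cm/s
compound 3 `Clc1ccc(-c2nc(-c3ccc4nc[nH]c4c3)no2)cc1`: 10.3 10^-6 cm/s

All three share one core and were measured in a physicochemical assay for permeability, using PAMPA, at pH 7.4; on this read-out higher numbers stand for higher permeability and lower numbers for lower permeability. Compound 3 stands second highest of the three numbers. Its nearest neighbour is compound 2: the step of a 1.1-fold lower number from compound 2 to compound 3 (0.04 log units; within the scatter) is within the scatter, so these two cannot be told apart. Compound 1 lies furthest away, and the gap between compound 3 and compound 1 is beyond the scatter.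

Compound 4 `OCCCCCc1ccc(-c2nc(-c3ccc4nc[nH]c4c3)no2)cc1` is not yet measured. It differs from compound 3 in one place: 5-hydroxypentyl in place of chloro on an aromatic carbon. Among the measured compounds shown here, only one measured step exists on the same aromatic carbon, the exchange of one halogen for another from compound 2 to compound 3, and that step was within the scatter. For the measured compounds named here, no measured compound carries a hydroxyl group or a chain of this length, so the measured steps give little direct guidance. On that thin basis a modest move downward is expected, a 2.6-fold lower number from compound 3 to compound 4 (0.41 log units; beyond the scatter), and compound 4 is estimated at 4 10^-6 cm/s, with a likely range from 1.5 10^-6 cm/s to 9 10^-6 cm/s.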

Compound 4, apparent permeability: 7.75 10^-6 cm/s
Compound 4: the middle estimate sits 1.9-fold (0.29 log units) below what was measured; the measured number falls inside the stated range.
By their numbers in this assay, from the lowest: compounds 1, 4, 3 and 2 (each within the scatter of the next, the first and the last beyond it).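

On this aromatic carbon, in this assay, the 5-hydroxypentyl chain stands in for a halogen with no readable difference: replacing chloro gives (a 1.3-fold lower number from compound 3 to compound 4 (0.12 log units; within the scatter)) and replacing bromo gives (a 1.4-fold lower number from compound 2 to compound 4 (0.16 log units; within the scatter)). The earlier compounds shown here showed only one halogen exchanged for another here, whereas these steps cover a much bigger exchange, from a single atom to a chain ending in a hydroxyl group, and still stay within the scatter. Nothing available explains why these values stay so close.

One chain cannot show whether its length or its hydroxyl group matters for this read-out. A plain pentyl chain without the hydroxyl, a shorter propyl chain, or a chain ending in an amine or a carboxylic acid remains an open case at this position.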